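Swapping fluoro for methoxy on the amide-bound phenyl ring

The source may hold more compounds than are shown below. What is called first, only, known or untested is meant among the compounds shown, and "the series" means these compounds.

Three compounds share one core and were tested in a functional assay on MCF7 cells (Homo sapiens) for antiproliferative activity, read by MTT assay, with a stated time of 72 h; a lower number here means a stronger inhibitor, a higher number a weaker inhibitor. Compound 1 `O=C1COc2ccc(-c3cccc(NS(=O)(=O)c4ccc(F)cc4)c3)cc2N1c1ccccc1` reaches only the assay limit, > 40000 nM, so no number is known for it. Compound 3 `COc1ncc(-c2ccc3c(c2)N(c2ccc(F)cc2)C(=O)CO3)cc1NS(=O)(=O)c1ccc(F)cc1` likewise sits at the limit of this assay, > 40000 nM. Among the compounds with values here, compound 2 `O=C1COc2ccc(-c3cnc(Cl)c(NS(=O)(=O)c4ccc(F)cc4)c3)cc2N1c1ccc(F)cc1` is the one member of the set with a real number in this assay, 32600 nM. Compound 1 and compound 3 share the same bound instead, (the limit of > 40000 nM in this assay, at which 2 of the 3 values shown sit).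

Compound 4 `COc1ccc(N2C(=O)COc3ccc(-c4cnc(Cl)c(NS(=O)(=O)c5ccc(F)cc5)c4)cc32)cc1` differs from compound 2 in one place: methoxy in place of fluoro on an aromatic carbon. Within the data shown here, the single measured step, an at least 1.2-fold higher number from compound 2 to compound 3 (0.08 log units; that floor lies within the scatter), also exchanges a group for methoxy, but on the other aromatic ring and in place of chloro, and its floor lies within the scatter. It therefore says little about the new exchange beyond suggesting that a methoxy did not bring a large gain there.

With compound 2 already near the limit, a step of about a 1.1-fold higher number from compound 2 to compound 4 (0.03 log units; within the scatter) is expected, within the scatter, and a fair chance remains that this assay reports only a limit. Compound 4 is thus estimated at 35000 nM, within a range from 15000 nM to 80000 nM.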

Compound 4, half-maximal inhibitory concentration: 36000 nM
Compound 4: middle estimate off by 1.0-fold (0.01 log units), on the low side; measured number inside the range.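

Changing 4-fluorophenyl to 4-methoxyphenyl gives a 1.1-fold higher number from compound 2 to compound 4 (0.04 log units; within the scatter) in this assay, so the two compounds cannot be told apart in this test. Within the data shown here, this is the first one-place change in the set with a real number at both ends, whereas the step to compound 3 ends at a limit and gives only a floor. At this position, para to a large group, methoxy brings two heavy atoms and a hydrogen-bond acceptor in place of the single fluorine, yet the antiproliferative read-out shows no clear change and both compounds remain close to the top of the measurable range: the limit of > 40000 nM in this assay, at which 2 of the 4 values shown sit.

The compounds shown do not tell whether any other group at this position, such as an amine, a carboxylic acid or a longer chain like butoxy, would give a clear gain in potency. With these values so close to the limit, they also leave open how far a change here could weaken the activity, since a drop much beyond this level would appear only as a limit.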